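Notes on replacing methoxy with trifluoromethyl

This account rests on a few compounds, and the source may have more. Where it says the series, first, only, none or still open, it means among the compounds named here.

In an ADME assay on BaF3 cells (Mus musculus) for antiproliferative activity, read by CCK-8 assay, with a stated time of 72 h (a lower number here means a stronger inhibitor of growth, a higher number a weaker inhibitor of growth), compound 1 (`O=C(CCSc1ccc2c(/C=C/c3ccccn3)n[nH]c2c1)Nc1cccc(F)c1`) gives 6590 nM and compound 2 (`COc1cccc(NC(=O)CCSc2ccc3c(/C=C/c4ccccn4)n[nH]c3c2)c1`) gives 3840 nM. For the measured compounds named here, these two numbers lie within the scatter of each other, so compound 2 cannot be separated from the only other measured compound. Compound 3 (`O=C(CCSc1ccc2c(/C=C/c3ccccn3)n[nH]c2c1)Nc1cccc(C(F)(F)F)c1`) has trifluoromethyl in place of methoxy on an aromatic carbon, meta to a large group: trifluoromethyl in place of methoxy on an aromatic carbon. Going by the values given here, one measured step bears on this change, also a swap of one group on an aromatic carbon: a 1.7-fold lower number from compound 1 to compound 2 (0.23 log units; within the scatter), with methoxy in place of fluoro. That single step gives no direction, and trifluoromethyl itself has not been measured in this series. In this assay, no step beyond the scatter is therefore expected. The estimated step is a 1.2-fold higher number from compound 2 to compound 3 (0.07 log units; within the scatter). For compound 3 the expected value is 4500 nM, with an estimated range of 1800 nM to 11000 nM.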

Compound 3, concentration for 50% growth inhibition: 2300 nM
Estimate against measurement, compound 3: 2.0-fold (0.29 log units) above; the range from low to high includes it.
By their numbers in this assay, from the lowest: compounds 3, 2 and 1 (each within the scatter of the next, the first and the last beyond it).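

In this assay, the swap at this position gives a 1.7-fold lower number from compound 2 to compound 3 (0.22 log units; within the scatter), so trifluoromethyl and methoxy cannot be told apart here. The series now has its first step at this position that clears the scatter, with trifluoromethyl in place of fluoro: a 2.9-fold lower number from compound 1 to compound 3 (0.46 log units; beyond the scatter), a modest step, and compound 2 lies within the scatter of both of the others. Nothing available accounts for this step.

Three groups at one position do not show whether the difference between fluoro and trifluoromethyl extends to other groups, and an amine, a carboxylic acid or a longer chain at this place would test that. Also open, going by these compounds, is whether the same step would appear with the shared core changed, since all three compounds carry the same core and the same linking chain.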